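Dropping the Benzyl from the Amide of Compound 2

The source may hold more compounds than are shown below. What is called first, only, known or untested is meant among the compounds shown, and "the series" means these compounds.

Compound 2 `O=C(Nc1ccc(-n2ccc3nc(C(=O)NCc4ccccc4)ccc32)cc1)Nc1cccc(Cl)c1Cl` belongs to a set of three urea-linked analogues that share one core and differ only in the aryl group on the urea nitrogen. In a functional assay on A375P cells (Homo sapiens) for cytotoxicity, read by MTT assay (a higher number here means a weaker inhibitor, a lower number a stronger inhibitor), compound 2 reaches only the limit of the assay and gives > 10000 nM as that limit. Compound 1 `O=C(Nc1ccc(-n2ccc3nc(C(=O)NCc4ccccc4)ccc32)cc1)Nc1ccc(Cl)c(C(F)(F)F)c1` gives 1100 nM in this assay, and compound 3 `O=C(Nc1ccc(-n2ccc3nc(C(=O)NCc4ccccc4)ccc32)cc1)Nc1cccc(C(F)(F)F)c1` gives 7900 nM there. Exchanging the aryl group on the urea gives an at least 9.0-fold higher number from compound 1 to compound 2 (0.95 log units; beyond the scatter) and a 7.2-fold higher number from compound 1 to compound 3 (0.86 log units; beyond the scatter), while the pair of compound 2 and compound 3 shows an at least 1.2-fold lower number from compound 2 to compound 3 (0.10 log units; that floor lies within the scatter). Compound 2 thus sits at the limit of > 10000 nM in this assay, at which 1 of the 3 values shown sits, and nothing more precise can be said of its position.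

Compound 4 `NC(=O)c1ccc2c(ccn2-c2ccc(NC(=O)Nc3cccc(Cl)c3Cl)cc2)n1` keeps the 2,3-dichlorophenyl urea of compound 2 and is altered on the other side of the core: hydrogen in place of benzyl on an amide-type nitrogen, so that benzylcarbamoyl becomes carbamoyl. None of the three measured steps touches the amide-type nitrogen; all concern the urea aryl, so they give no direct guide to the size or direction of this change. Starting from a value already at the assay limit, compound 4 is expected to give about 15000 nM in this assay, within a range of 4000 nM to 60000 nM, and the step that the limit leaves unreadable from compound 2 to compound 4 is estimated to stay within the scatter, with another limit the most likely report.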

Compound 4, half-maximal inhibitory concentration: 4600 nM
Compound 4: middle estimate off by 3.3-fold (0.51 log units), on the high side; the measured number falls inside the stated range.
By their numbers in this assay, from the lowest: compound 1; then compounds 4 and 3 (each within the scatter of the next). At a limit, above all of these: compound 2.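

For the compounds shown here, none of the earlier steps touched the amide-type nitrogen, and this pair is the first to do so: with the 2,3-dichlorophenyl urea held constant, hydrogen in place of benzyl, which turns benzylcarbamoyl into carbamoyl, gives an at least 2.1-fold lower number from compound 2 to compound 4 (0.33 log units; beyond the scatter) in this assay. The change therefore has a direction that can be read, and the benzyl on this nitrogen is not required for compound 4 to give a measured number in this assay. The true size of the step remains unknown and the printed figure is only a floor, because compound 2 stands at a limit of the assay rather than at a number: the limit of > 10000 nM in this assay, at which 1 of the 4 values shown sits.

Going by these compounds alone, only this one pair of compounds spans the amide-type nitrogen, so it remains open whether the same exchange would move the number in the same direction with the 4-chloro-3-(trifluoromethyl)phenyl urea of compound 1. Also open is how a methyl group or a phenethyl chain on this nitrogen would compare with hydrogen and benzyl, since the compounds shown offer only those two end points.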